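The source may hold more compounds than are shown below. What is called first, only, known or untested is meant among the compounds shown, and "the series" means these compounds.

- Compound 1 `CC(C)=CCc1cc(C(=O)Nc2cc3ccc(OCCCN4CCCC4)c(C)c3oc2=O)ccc1O` gives 720 nM in a functional assay on SK-BR-3 cells (Homo sapiens) for antiproliferative activity; a higher number here means a weaker inhibitor, a lower number a stronger inhibitor
- Compound 2 `CC(C)=CCc1cc(C(=O)Nc2cc3ccc(OCCCNC(C)C)c(C)c3oc2=O)ccc1O` gives 750 nM in this assay
- Compound 3 `CC(C)=CCc1cc(C(=O)Nc2cc3ccc(OCCCN(C)C(C)C)c(C)c3oc2=O)ccc1O` gives 570 nM in this assay

Compound 3 stands within the scatter of both other compounds, so its number does not set it apart from either. The next compound, compound 4 `CC(C)=CCc1cc(C(=O)Nc2cc3ccc(OCCCNC4CCCCC4)c(C)c3oc2=O)ccc1O`, differs from it in one group: cyclohexylamino in place of isopropyl(methyl)amino on a saturated chain carbon, three bonds along the chain from an oxygen on an aromatic ring. Here cyclohexylamino takes the place of isopropyl(methyl)amino on a saturated chain carbon, three bonds along the chain from an oxygen on an aromatic ring.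

Among the compounds with values here, three measured steps bear on this change. Replacing pyrrolidin-1-yl gave a 1.0-fold higher number from compound 1 to compound 2 (0.02 log units; within the scatter) and a 1.3-fold lower number from compound 1 to compound 3 (0.10 log units; within the scatter), while methyl in place of hydrogen on an amine nitrogen gave a 1.3-fold lower number from compound 2 to compound 3 (0.12 log units; within the scatter). All three lie within the scatter, so among these compounds no change of amine group has yet moved the number beyond it. Within the data shown here, no measured compound carries a cyclohexylamino group, however, so that group itself remains untested, and the range must stay wide.

The expected change is a 1.1-fold higher number from compound 3 to compound 4 (0.02 log units; within the scatter) and no step beyond the scatter is expected. For compound 4 the estimated value is 600 nM with an expected range of 300 nM to 1200 nM.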

Compound 4, half-maximal inhibitory concentration: 660 nM
Compound 4: middle estimate off by 1.1-fold (0.04 log units), on the low side; measured number inside the range.
By their numbers in this assay, from the lowest: compounds 3, 4, 1 and 2 (each within the scatter of the next).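

In this assay, cyclohexylamino at this place on the chain gives a 1.2-fold higher number from compound 3 to compound 4 (0.06 log units; within the scatter) and a 1.1-fold lower number from compound 2 to compound 4 (0.06 log units; within the scatter) and also a 1.1-fold lower number from compound 1 to compound 4 (0.04 log units; within the scatter) so the first amine group bearing a six-membered non-aromatic ring of carbon only does not separate from any of the three earlier amines. The change also adds heavy atoms and exchanges a nitrogen without a hydrogen-bond donor for one with a hydrogen-bond donor, and the number still does not leave the scatter, so the flat picture from compounds 1, 2 and 3 now extends to a larger cyclic substituent on the amine nitrogen and no compound shown goes against it. Nothing measured here says why the number holds so steady across these four amine groups.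

The compounds shown leave open whether a morpholin-4-yl or piperazin-1-yl group, a primary amine or a carboxylic acid at this same place on the chain would move the number beyond the scatter. They also leave open whether a 2-carbon or 4-carbon chain in place of the 3-propyl chain, carrying any of these amines, would do so.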